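Removing the trifluoromethyl group from compound 3

The source may report more compounds than this note shows. Statements on the series, on what has been measured and on what is new or still open speak of the compounds shown alone.

The study covers a small set of compounds sharing one core, all tested in an ADME assay on HUVEC cells (Homo sapiens) for inhibition, read by MTT assay, with a stated time of 48 h; a higher number here means a weaker inhibitor, a lower number a stronger inhibitor. Compound 1 `COc1cc(/C=N/Nc2nc(-c3ccc(Br)cc3)cs2)cc(Br)c1OC` carries a 4-bromophenyl group. In this assay compound 1 gives > 100000 nM, which is a limit of the assay and not a number. Compound 2 `COc1cc(/C=N/Nc2nc(-c3cccc(Br)c3)cs2)cc(Br)c1OC` carries a 3-bromophenyl group, and in this assay compound 2 gives > 100000 nM, again a limit. Compound 3 `COc1cc(/C=N/Nc2nc(-c3ccc(C(F)(F)F)cc3)cs2)cc(Br)c1OC` carries a trifluoromethyl group on an aromatic carbon, and in this assay compound 3 gives > 100000 nM, also a limit. The step that the two limits leave unreadable from compound 1 to compound 2 and the step that the two limits leave unreadable from compound 1 to compound 3 are therefore unreadable, since all three values sit at the limit of > 100000 nM in this assay, at which 3 of the 3 values shown sit. Compound 3 thus stands at the limit together with the other two, with no readable order among them.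

Compound 4 `COc1cc(/C=N/Nc2nc(-c3ccccc3)cs2)cc(Br)c1OC` differs from compound 3 by hydrogen in place of trifluoromethyl on an aromatic carbon. Among the measured compounds shown here, no measured step bears directly on this change, and the two measured steps are unreadable, so no size or direction can be taken from them. Three values at the limit give no sign that varying this aromatic group brings inhibition into the measurable range. Compound 4 is therefore expected to stay at the limit, with an estimated step that the limit leaves unreadable from compound 3 to compound 4. The estimate for compound 4 is 150000 nM, with a range from 50000 nM to 500000 nM.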

Compound 4, half-maximal inhibitory concentration: > 100000 nM
Compound 4: a limit, no number; the forecaster's own chance of this, stated with the estimate: 85%; the middle value is on the limit's open side.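

In this assay compound 4 gives > 100000 nM, which is a limit of the assay and not a number. Its steps from compound 1, compound 2 and compound 3 therefore cannot be read: the limit of > 100000 nM in this assay, at which 4 of the 4 values shown sit.

The compounds shown leave open whether any change to the shared core would bring inhibition into the measurable range of this assay.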